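A few compounds are considered here, and "the series" means these few. Any claim that something is new, unique, unknown or untested is made for them only; others in the source may bear on it.

Compound 2, `CN(C)/N=C1/CN(CC(=O)Nc2cccc(-c3cnn(C)c3)c2)C(=O)C(Cc2ccccc2Cl)CN1`, is the starting point of this step. Within the data shown here, in an assay on isolated protein for inhibition of kallikrein-7 (Homo sapiens), read by fluorescence, with stated times of 10 min and 30 min (on this read-out lower numbers stand for stronger inhibition and higher numbers for weaker inhibition), compound 2 gives 2500 nM, the only number it has there, alongside one further entry that yields no single figure. Its close relative compound 1, `CN(C)/N=C1/CN(CC(=O)Nc2cccc(-c3cnn(C)c3)c2)C(=O)C(Cc2c(Cl)cccc2Cl)CN1`, has been measured repeatedly in the same assay: compound 1 gives 790 nM; > 30000 nM; 380 nM (3 entries). Compound 3, `CN(C)/N=C1/CN(CC(=O)Nc2cccc(-c3cnn(C)c3)c2)C(=O)C(Cc2c(F)cccc2F)CN1`, has not yet been tested. It differs from compound 2 in one place: 2,6-difluorophenyl in place of 2-chlorophenyl on a saturated chain carbon bound to a saturated ring carbon. Among the measured compounds shown here, no measured pair isolates this change, so its size can only be expected. Compound 3 is estimated at 2000 nM, with a likely range from 600 nM to 6000 nM. The expected step from compound 2 to compound 3, a 1.3-fold lower number from compound 2 to compound 3 (0.10 log units; within the scatter), is judged not to exceed the usual scatter in either direction.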

Compound 3, half-maximal inhibitory concentration: 6900 nM
For compound 3 the middle estimate is 3.5-fold (0.54 log units) below the measured one, and the stated range ends below it.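

In this assay, 2,6-difluorophenyl in place of 2-chlorophenyl on a saturated chain carbon bound to a saturated ring carbon gives a 2.8-fold higher number from compound 2 to compound 3 (0.44 log units; beyond the scatter). Among these compounds, this is the first step that can be read at this position, and it shows that the position responds to a change of this kind, although the step is modest. Its size should be read with care because repeated entries in this assay can spread widely, and one entry of compound 1 is a limit of the assay and not a number: the several entries of compound 1 in this assay, 790 nM; > 30000 nM; 380 nM (3 entries)

The compounds shown leave open whether the higher number goes with the loss of chlorine or with the presence of two fluorines. Neither a 2-fluorophenyl group nor an unsubstituted phenyl group stands among them to separate these two readings.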